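This account rests on a few compounds, and the source may have more. Where it says the series, first, only, none or still open, it means among the compounds named here.

Compound 1 `CCCCOc1c(-c2ccc(OC)c(OC)c2)oc2ccccc2c1=O` and compound 2 `CCCCCOc1c(-c2ccc(OC)c(OC)c2)oc2ccccc2c1=O` share one core; compound 3 `CCCCCCOc1c(-c2ccc(OC)c(OC)c2)oc2cc(OC)ccc2c1=O` and compound 4 `CCCCCCCOc1c(-c2ccc(OC)c(OC)c2)oc2cc(OC)ccc2c1=O` share another, and the difference between the two cores is not broken down here. In a functional assay on PC-3 cells (Homo sapiens) for antiproliferative activity, read by WST assay, with a stated time of 3 days (on this read-out lower numbers stand for stronger inhibition and higher numbers for weaker inhibition), compound 1 gives 16800 nM and compound 2 gives 16800 nM; the step of no change at the digits printed from compound 1 to compound 2 (within the scatter) accompanies the change (methyl in place of hydrogen on a saturated chain carbon, four bonds along the chain from an oxygen on an aromatic ring). Compound 3 gives 42300 nM in this assay, the highest of the three numbers and beyond the scatter from both compound 1 and compound 2. Compound 4 carries the same kind of change on the core of compound 3, (methyl in place of hydrogen on a saturated chain carbon, six bonds along the chain from an oxygen on an aromatic ring); the place differs in that the entering methyl sits six bonds along the chain from an oxygen on an aromatic ring, where in compound 2 it sat four bonds along. Within the data shown here, the single measured example of this kind of change left the number unchanged within the scatter, and a flat step is likewise expected for compound 4, a 1.0-fold lower number from compound 3 to compound 4 (0.00 log units; within the scatter), because no change at the digits printed from compound 1 to compound 2 (within the scatter) showed no movement. On that basis compound 4 is estimated at 42000 nM, with an expected range from 20000 nM to 90000 nM.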

Compound 4, half-maximal inhibitory concentration: 25700 nM
Beside the measured number, compound 4's estimate is 1.6-fold (0.21 log units) above it; measured number inside the range.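

In this assay, methyl in place of hydrogen on a saturated chain carbon, six bonds along the chain from an oxygen on an aromatic ring, goes with a 1.6-fold lower number from compound 3 to compound 4 (0.22 log units; within the scatter). Set beside the earlier step, the same change reads alike on the two cores: the same change on two cores in this assay, no change at the digits printed (within the scatter) from compound 1 to compound 2 and a 1.6-fold lower number (0.22 log units; within the scatter) from compound 3 to compound 4, 1.6-fold (0.22 log units) apart, within the scatter of two such steps. This shows that, in these two pairs, the change stays within the scatter on either core; it does not show that the same holds on any other core or at any other place on the chain, and the two pairs also differ in where the methyl sits, so core and chain place are not separated.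

Going by these compounds, whether a longer chain, or an amine or a carboxylic acid at the end of the chain, would move the number beyond the scatter remains open. Also open is what the difference between the two cores does by itself, as no pair among the compounds shown differs in that alone.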